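The source may hold more compounds than are shown below. What is called first, only, known or untested is meant among the compounds shown, and "the series" means these compounds.

Measured compounds: compound 1 `CCN(CC)S(=O)(=O)c1ccc(S(=O)(=O)N2CCC[C@@H](C(=O)N[C@H]3CCOC3)C2)cc1` and compound 2 `CCN(CC)S(=O)(=O)c1ccc(S(=O)(=O)N2CCC[C@@H](C(=O)N[C@H]3CC[C@@H](OC)CC3)C2)cc1`.

In a functional assay on MIA PaCa-2 cells (Homo sapiens) for inhibition, read by MTT assay, with a stated time of 3 days (a lower number here means a stronger inhibitor, a higher number a weaker inhibitor), compound 1 gives only a limit, > 10000 nM. In this assay compound 2 likewise gives only a limit, > 10000 nM. Compound 2 therefore stands at the limit of this assay, where the other value shown also sits (the limit of > 10000 nM in this assay, at which 2 of the 2 values shown sit).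

The unmeasured compound 3 `CCN(CC)S(=O)(=O)c1ccc(S(=O)(=O)N2CCC[C@@H](C(=O)N[C@@H]3CCOC3)C2)cc1` differs from compound 2 by oxolan-3-yl in place of 4-methoxycyclohexyl on an amide-type nitrogen. For the measured compounds named here, the one measured step that bears on this change is its reverse, a step that the two limits leave unreadable from compound 1 to compound 2, whose size cannot be read because both of its ends sit at the limit (the limit of > 10000 nM in this assay, at which 2 of the 2 values shown sit). No readable step therefore tells the direction or size of the change in this assay, and compound 3 is expected to stay at the limit rather than move beyond the scatter. Compound 3 is estimated at 15000 nM, within 5000 nM to 50000 nM, which means an expected step that the limit leaves unreadable from compound 2 to compound 3.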

Compound 3, half-maximal inhibitory concentration: > 10000 nM
Compound 3 gave a limit, no number (the forecaster's own chance of this, stated with the estimate: 85%); the middle value does not contradict the limit.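

In this assay compound 3 also gives only a limit, so neither its step from compound 2 nor its step from compound 1 can be read: the limit of > 10000 nM in this assay, at which 3 of the 3 values shown sit.

The compounds shown leave open whether the group on the amide-type nitrogen, or the configuration that separates compound 1 from compound 3, changes activity in this assay.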